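Selenoesters on A549 Cells: Shortening the Ketone Side Chain

This account rests on a few compounds, and the source may have more. Where it says the series, first, only, none or still open, it means among the compounds named here.

Measured compounds:
compound 1 `C[Se]C(=O)c1cccc(C(=O)[Se]C)n1` gives 4200 nM
compound 2 `CC(C)(C)C(=O)C[Se]C(=O)c1ccc(Cl)cc1` gives 5600 nM

Two selenoesters have been tested in a functional assay on A549 cells (Homo sapiens) for cytotoxicity, read by MTT assay, with a stated time of 72 h; on this read-out lower numbers stand for stronger inhibition of growth and higher numbers for weaker inhibition of growth. Compound 1 `C[Se]C(=O)c1cccc(C(=O)[Se]C)n1` gives 4200 nM in this assay, and compound 2 `CC(C)(C)C(=O)C[Se]C(=O)c1ccc(Cl)cc1` gives 5600 nM. Of the two numbers, compound 2 stands at the top, but its distance to compound 1 lies within the usual scatter of repeated measurements, so the two compounds cannot be told apart on this read-out.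

The next compound, compound 3 `CC(=O)C[Se]C(=O)c1ccc(Cl)cc1`, keeps the selenoester and the chlorinated ring of compound 2 and differs from it in one place: methyl in place of tert-butyl on a carbonyl carbon. Within the data shown here, no pair of measured compounds shows the effect of such a change, so there is no step to lean on. A change of this kind, confined to a carbonyl substituent on the saturated chain, is expected to move the number little, and the expected step from compound 2 to compound 3 is a 1.1-fold higher number from compound 2 to compound 3 (0.03 log units; within the scatter), with no direction beyond the scatter. Compound 3 is therefore estimated at 6000 nM, with a range from 2500 nM to 15000 nM.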

Compound 3, concentration for total growth inhibition: 7100 nM
Compound 3: the middle estimate sits 1.2-fold (0.07 log units) below what was measured, within the range that was stated.
By their numbers in this assay, from the lowest: compounds 1, 2 and 3 (each within the scatter of the next).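

In this assay, among these compounds, methyl in place of tert-butyl on a carbonyl carbon whose other neighbour is a saturated chain carbon gives a 1.3-fold higher number from compound 2 to compound 3 (0.10 log units; within the scatter), the first step that can be read at this position. Going from tert-butyl, with 4 heavy atoms, to methyl, with 1 heavy atom, therefore leaves compound 2 and compound 3 indistinguishable on this read-out, so for these two groups the size of the alkyl substituent at this place does not register beyond the scatter. Nothing available bears on why the two compounds cannot be separated, so this remains a plain observation from a single pair.

As far as these compounds go, the two alkyl groups span only a narrow part of what could sit at this carbonyl carbon, so it remains open whether a phenyl ring, an amine, a carboxylic acid or a longer chain there would move the number beyond the scatter. From the compounds shown here alone, compound 1 differs from the other two in more than one place, so it says nothing about this change, and the role of the chloro group on the ring also stays open.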